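The compounds below may be only part of what the source reports. "The series", "measured", "known", "first", "only" and "open" are said of these compounds alone.

Compound 1 `COc1cc(OCc2cccc(CCc3ccccc3)c2)c2cc(-c3cn4nc(OC)sc4n3)oc2c1` holds the lower of the two numbers recorded so far in a functional assay on HEK293 cells for antagonist activity at proteinase-activated receptor 4 (Homo sapiens), read by FLIPR and calcium flux, with a stated time of 30 min (a higher number here means a weaker inhibitor, a lower number a stronger inhibitor), where compound 1 gives 2.4 nM. For the measured compounds named here, the only other measured compound is compound 2 `COc1nn2cc(-c3cc4c(OC)cccc4o3)nc2s1`, which in this assay gives 7.6 nM, a number that lies beyond the usual scatter above that of compound 1. Going by the values given here, no step between measured compounds that differ in a single place is known, so no one substituent has yet been isolated in its effect. Compound 3 `COc1cc(OCc2cccc(O)c2)c2cc(-c3cn4nc(OC)sc4n3)oc2c1` differs from compound 1 in one place: hydroxy in place of phenethyl on an aromatic carbon. The two measured values show only that compound 1, which carries the phenethyl on its side arm, sits lower than compound 2, which lacks that arm altogether; how much of that rests on the phenethyl itself is not shown. The expected step of a 6.3-fold higher number from compound 1 to compound 3 (0.80 log units; beyond the scatter) is upward, toward a weaker inhibitor, by a modest margin that may just exceed the scatter. Compound 3 is therefore estimated at 15 nM in this assay, with a range running from 4 nM to 60 nM.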

Compound 3, half-maximal inhibitory concentration: 3.1 nM
Compound 3: the middle estimate sits 4.8-fold (0.68 log units) above what was measured; measured number below the stated range.
By their numbers in this assay, from the lowest: compounds 1 and 3 (each within the scatter of the next); then compound 2.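

Putting hydroxy in place of phenethyl on an aromatic carbon, meta to a large group, gives a 1.3-fold higher number from compound 1 to compound 3 (0.11 log units; within the scatter) in this assay and so leaves the number inside the scatter. For the compounds shown here, this is the first single-place comparison, and it shows that at this position a group of 8 heavy atoms with its aromatic ring can give way to a single oxygen bearing a hydrogen-bond donor with no change that this read-out can separate from repeat measurement, so the phenethyl is not required for a number of this size on this core. Nothing available explains why so large a change in the group leaves the number within the scatter.

As far as these compounds go, whether this tolerance extends to other groups on the same aromatic carbon, such as a methoxy, an amine, a carboxylic acid or a longer chain, remains open. Also open, from the compounds shown here alone, is what the rest of the side arm contributes, since both compounds in this comparison keep it and only the group at its far end has been exchanged.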